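This account rests on a few compounds, and the source may have more. Where it says the series, first, only, none or still open, it means among the compounds named here.

Compound 1, `C=C(CCO)C(=O)Nc1ccccc1`, in an ADME assay for pharmacokinetics, read by LC-MS, in phosphate buffer, with a stated time of 120 min, at pH 7.4, tested at 1 uM, in the presence of a further agent that is not named here (on this read-out lower numbers stand for a shorter-lived compound and higher numbers for a longer-lived compound), gives > 8.53 h, which is a limit of the assay rather than a number.
Compound 2, `C=C(C)C(=O)Nc1ccccc1`, in this assay gives > 8.53 h, again a limit of the assay.

Both measured values sit at the limit of > 8.53 h in this assay, at which 2 of the 2 values shown sit, so compound 2 stands at the limit and not at a measured number. For the measured compounds named here, the only measured step, a step that the two limits leave unreadable from compound 1 to compound 2, is therefore unreadable in size and direction. Compound 3, `C=C(F)C(=O)Nc1ccccc1`, differs from compound 2 in one place: fluoro in place of methyl on a double-bonded chain carbon bound to a carbonyl carbon. No measured step bears on this change, since the one step shown cannot be read and no other pair shares this change. The expectation for compound 3 rests only on compound 2 standing at the limit; a step of an at least 1.7-fold lower number from compound 2 to compound 3 (0.23 log units; that floor lies within the scatter) is estimated, with wide uncertainty. Compound 3 is expected to give about 5 h, in a range from 1 h to 8.53 h.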

Compound 3, half-life: > 8.53 h
Compound 3: only a limit was reported (the forecaster's own chance of this, stated with the estimate: 45%); middle value at least 1.7-fold (0.23 log units) away from the limit.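

Compound 3 gives a limit rather than a number, as do compound 1 and compound 2, so no step among these three compounds can be read: the limit of > 8.53 h in this assay, at which 3 of the 3 values shown sit. On these data alone, how long each compound really lasts in this assay stays open, and so does whether 2-hydroxyethyl, methyl or fluoro changes that.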